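Hydroxy in place of 5-methylfuran-2-yl in compound 3

This account rests on a few compounds, and the source may have more. Where it says the series, first, only, none or still open, it means among the compounds named here.

Compound 1 `COc1ccc(/C=C/C(=O)C(=Cc2ccc(F)cc2)C(=O)/C=C/c2ccc(OC)c(OC)c2)cc1OC`: 550 nM
Compound 2 `COc1ccc(/C=C/C(=O)C(=Cc2ccc(C)o2)C(=O)/C=C/c2ccc(OC)c(OC)c2)cc1OC`: 1310 nM

In a functional assay on A549 cells (Homo sapiens) for inhibition, read by sulforhodamine B assay, with a stated time of 48 h (on this read-out lower numbers stand for stronger inhibition of growth and higher numbers for weaker inhibition of growth), compound 2 gives 1310 nM, the higher of the two numbers, so it is the weaker growth inhibitor of this pair. Compound 3 `COc1ccc(/C=C/C(=O)C(=CO)C(=O)/C=C/c2ccc(OC)c(OC)c2)cc1OC` has not yet been measured. It differs from compound 2 as follows: hydroxy in place of 5-methylfuran-2-yl on a double-bonded chain carbon bound to a double-bonded chain carbon. In words, hydroxy stands in place of 5-methylfuran-2-yl on a double-bonded chain carbon bound to a double-bonded chain carbon, so the ring is lost.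

Among the compounds with values here, only one measured step bears on this place: a 2.4-fold higher number from compound 1 to compound 2 (0.38 log units; beyond the scatter). That step is modest, and in it one ring replaced another, so it offers only a rough guide to losing the ring altogether. A similarly modest rise in this assay is therefore expected, with real uncertainty about direction. The expected change is a 1.5-fold higher number from compound 2 to compound 3 (0.18 log units; within the scatter). For compound 3 the estimated value is 2000 nM, with an expected range from 600 nM to 6500 nM.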

Compound 3, concentration for 50% growth inhibition: > 25000 nM
Compound 3 gave a limit, no number; the forecaster's own chance of this, stated with the estimate: 5%; at least 12-fold (1.09 log units) between middle value and limit.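

In this assay compound 3 gives only a limit of the assay, not a number: the limit of > 25000 nM in this assay, at which 1 of the 3 values shown sits. Replacing the ring with hydroxy on this double-bonded chain carbon therefore costs far more than replacing one ring with another, which gave a 2.4-fold higher number from compound 1 to compound 2 (0.38 log units; beyond the scatter); the new change gives an at least 19-fold higher number from compound 2 to compound 3 (1.28 log units; beyond the scatter) and, measured against the 4-fluorophenyl compound, an at least 45-fold higher number from compound 1 to compound 3 (1.65 log units; beyond the scatter). Among these three compounds, growth inhibition reaches a measured number only when a ring sits at this place, so this position tolerates a change of ring far better than this change to hydroxy.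

This single change removes the ring and brings in hydroxy together, and the compounds shown do not separate the two. As far as these compounds go, whether an amine or a longer carbon chain at this place would restore growth inhibition without any ring remains open.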